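The source may report more compounds than this note shows. Statements on the series, on what has been measured and on what is new or still open speak of the compounds shown alone.

The two compounds measured so far, with their values in a functional assay on the whole organism for inhibition, with Rattus norvegicus as the target, read by paw edema, in the formalin test, with a stated time of 4 h, at a dose of 100 mg/kg by the intraperitoneal route; on this read-out higher numbers stand for more inhibition at the one dose given (going by the name of the read-out) and lower numbers for less inhibition:

compound 1, `O=c1cc(CNc2nc(-c3cc4cc(Br)cc(Br)c4oc3=O)cs2)c2cc(Cl)ccc2[nH]1`: 29.8%
compound 2, `O=c1cc(CNc2nc(-c3cc4cc(Br)cc(Br)c4oc3=O)cs2)c2ccc(Cl)cc2[nH]1`: 34.5%

Compound 1 gives the lower of the two numbers, and compound 2 sits only a little above it. That gap lies within the scatter of repeated measurements of this kind, so the two compounds cannot be told apart on this read-out, and neither can be called the stronger. Going by the values given here, no step between two measured compounds that differ in a single place has been recorded here, so there is no measured change to lean on when judging the size of a new one.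

Compound 3, `O=c1cc(CNc2nc(-c3cc4cc(Br)ccc4oc3=O)cs2)c2cc(Cl)ccc2[nH]1`, is related to compound 1 by hydrogen in place of bromo on an aromatic carbon. One of the two bromo groups of the shared core leaves and a hydrogen takes its place, while the other bromo group remains. Without a comparable measured step, the change expected in this assay is none beyond the scatter, with perhaps a small dip. The estimate for compound 3 is 27%, with a range from 14% to 40%. As a step, this expected value means a number 2.8 percentage points lower from compound 1 to compound 3 (within the scatter).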

Compound 3, a percentage reported as inhibition, in the whole organism at one dose (the size of the read-out at that dose, not a potency): 19.8%
For compound 3 the middle estimate is 7.2 percentage points above the measured one; measured number inside the range.
By their numbers in this assay, from the lowest: compounds 3, 1 and 2 (each within the scatter of the next, the first and the last beyond it).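

Swapping one of the two bromo groups for hydrogen, on the aromatic carbon ortho to a fused ring and meta to the other bromo group, gives the first single-place step in this assay: a number 10 percentage points lower from compound 1 to compound 3 (within the scatter). Because that step stays within the scatter, compound 1 and compound 3 cannot be told apart on this read-out, so at this single dose the bromo group at this position is not shown to be needed for the inhibition seen, though a modest real effect cannot be excluded either. Nothing available here bears on the size of this step.

As far as these compounds go, it remains open whether a different group on this same carbon, such as a methoxy group or an amine, would give a number that stands clear of compound 1 beyond the scatter. From the compounds shown here alone, it is also open whether the remaining bromo group could give way to hydrogen with a similarly small step, and whether the same swap would behave alike with the chloro group placed as in compound 2.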